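Adding Fluorine to the Fused Ring of Compound 1

This account rests on a few compounds, and the source may have more. Where it says the series, first, only, none or still open, it means among the compounds named here.

Of the compounds shown here, two that share a core have been measured in an assay for inhibition of Alpha amylase (Homo sapiens), with a stated time of 10 min; a higher number here means a weaker inhibitor, a lower number a stronger inhibitor. Compound 1, `COc1ccc(Br)c(-c2nc3ccccc3[nH]2)c1O`, gives 2480 nM. Compound 2, `Oc1ccc(-c2nc3cc(F)ccc3[nH]2)c(O)c1`, gives 2980 nM. Compound 1 has the lowest of the two numbers, but its nearest neighbour, compound 2, sits within the scatter of the method, so the two cannot be told apart.

Compound 3, `COc1ccc(Br)c(-c2nc3cc(F)ccc3[nH]2)c1O`, has not yet been measured. It differs from compound 1 by fluoro in place of hydrogen on an aromatic carbon; it sits on an aromatic carbon of a six-membered aromatic ring of carbon only, part of a fused system of two rings, meta to a fused ring and para to a fused ring.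

Among the measured compounds shown here, no measured pair shows this change on its own. Compound 2 carries the same fluoro on its fused ring and shows a value close to that of compound 1, so little movement beyond the scatter is expected. Compound 3 is estimated at 2500 nM, within a range of 1200 nM to 5200 nM, corresponding to an expected step of a 1.0-fold higher number from compound 1 to compound 3 (0.00 log units; within the scatter).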

Compound 3, half-maximal inhibitory concentration: 2170 nM
Estimate against measurement, compound 3: 1.2-fold (0.06 log units) above, and the stated range covers the measured number.
By their numbers in this assay, from the lowest: compounds 3, 1 and 2 (each within the scatter of the next).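

In this assay, among the compounds shown here, fluoro in place of hydrogen on an aromatic carbon can now be read on its own for the first time, as a 1.1-fold lower number from compound 1 to compound 3 (0.06 log units; within the scatter). At this place, meta to a fused ring and para to a fused ring, the swap produces no difference that can be told from the scatter of repeated measurements, so a single fluorine is accepted here on the core of compound 1 without a readable gain or loss. No measurement at hand explains why the step is so small.

From the compounds shown here alone, it remains open whether a different group at the same place, such as an amine or a carboxylic acid, would move the number beyond the scatter. Going by these compounds, it is also open whether fluoro would give the same result at other places on this fused ring.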